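Cyclopentyl for ethyl on the ring amine

The source may report more compounds than this note shows. Statements on the series, on what has been measured and on what is new or still open speak of the compounds shown alone.

In an in vitro ADME assay on microsomes from liver (Homo sapiens) for pharmacokinetics (on this read-out lower numbers stand for slow clearance and higher numbers for fast clearance), compound 1 (`Cc1ccc(S(=O)(=O)N2C=CNC(=O)[C@H]2CC(=O)NC2CCCCC2C)cc1`) gives 212 mL.min-1.g-1 as a measured number. Compound 2 (`CCN1CC[C@H](NC(=O)C[C@@H]2C(=O)NC=CN2S(=O)(=O)c2ccc(C)cc2)C(C)(C)C1`) gives < 50 mL.min-1.g-1 and this is a limit of the assay, not a number. From the compounds shown here alone, compound 2 therefore stands at the limit of < 50 mL.min-1.g-1 in this assay, at which 1 of the 2 values shown sits, and its true position is unknown.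

Compound 3 (`Cc1ccc(S(=O)(=O)N2C=CNC(=O)[C@H]2CC(=O)N[C@H]2CCN(C3CCCC3)CC2(C)C)cc1`) carries cyclopentyl in place of ethyl on an amine nitrogen in a ring. Within the data shown here, one measured step bears on this only indirectly: the change on the amide-type nitrogen (an at least 4.2-fold lower number from compound 1 to compound 2 (0.62 log units; beyond the scatter)), which lies beyond the scatter. Among the measured compounds shown here, no measured step varies the substituent on the amine nitrogen itself, so that step sets a scale and not a direction. Expected in this assay is a small rise, an at least 1.4-fold higher number from compound 2 to compound 3 (0.14 log units; that floor lies within the scatter) as estimated, staying short of the number for compound 1. For compound 3 the expected value is an estimated 70 mL.min-1.g-1 (range 30 mL.min-1.g-1 to 170 mL.min-1.g-1).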

Compound 3, intrinsic clearance in microsomes: < 14 mL.min-1.g-1
Compound 3: a limit, no number (the forecaster's own chance of this, stated with the estimate: 40%); at least 5.0-fold (0.69 log units) between middle value and limit.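

In this assay compound 3 gives < 14 mL.min-1.g-1, a limit and not a number. Compound 2 is also at a limit, and the step from compound 2 to compound 3 cannot be read. Still open, from the compounds shown here alone, is what cyclopentyl in place of ethyl on an amine nitrogen in a ring changes in this read-out.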